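Bromo for Fluoro: an Expected Step in Cell Cytotoxicity

A few compounds are considered here, and "the series" means these few. Any claim that something is new, unique, unknown or untested is made for them only; others in the source may bear on it.

Measured compounds in a functional assay on DLD-1 cells (Homo sapiens) for cytotoxicity, read by resazurin assay, with a stated time of 48 h; a lower number here means that less compound is needed, a higher number that more compound is needed for the effect:
- compound 1, `COc1c(Br)cccc1C(=O)Nc1ccc(Sc2nc3ccccc3s2)c(Cl)c1`, gives 10000 nM
- compound 2, `COc1ccc(S(=O)(=O)Nc2ccc3oc(-c4ccc(NS(=O)(=O)c5cc(F)ccc5OC)cc4)nc3c2)cc1`, gives 18000 nM
- compound 3, `O=S(=O)(Nc1ccc(-c2nc3cc(NS(=O)(=O)c4ccc(Br)cc4)ccc3o2)cc1)c1ccc(Br)cc1`, gives 16000 nM

Compound 2 carries the highest of the three numbers in this assay, but its gap to compound 3 and its gap to compound 1 both lie within the usual scatter, so the three compounds cannot be ranked against one another on these data.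

Compound 4, `COc1ccc(S(=O)(=O)Nc2ccc3oc(-c4ccc(NS(=O)(=O)c5cc(Br)ccc5OC)cc4)nc3c2)cc1`, has not yet been measured. It differs from compound 2 in one place: bromo in place of fluoro on an aromatic carbon. Compound 2 and compound 3 already show that a fluoro and a bromo substituent on sulfonamide-bearing compounds of this shape land within the scatter of each other, although those two compounds differ in more than this one place. Among the measured compounds shown here, no measured pair isolates this exchange.

With compound 2 at 18000 nM, the account expects no step beyond the scatter: the estimated step from compound 2 to compound 4 in this assay is a 1.2-fold lower number from compound 2 to compound 4 (0.08 log units; within the scatter). Compound 4 is therefore expected to give about 15000 nM in this assay, within a range from 6000 nM to 40000 nM.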

Compound 4, half-maximal effective concentration: 15000 nM
Compound 4: middle estimate and measured number agree at the digits printed, and the stated range covers the measured number.
By their numbers in this assay, from the lowest: compounds 1, 4, 3 and 2 (each within the scatter of the next).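

Among the compounds shown here, the pair of compound 2 and compound 4 is the first to isolate a single exchange in this assay: replacing 5-fluoro-2-methoxyphenyl with 5-bromo-2-methoxyphenyl gives a 1.2-fold lower number from compound 2 to compound 4 (0.08 log units; within the scatter). For the compounds shown here, at this position, para to a methoxy group, the two halogens therefore cannot be told apart in this assay, which the earlier compounds, differing in more than one place, could not show. Nothing measured here bears on why the exchange behaves this way.

On these data alone, whether this position responds to anything other than a halogen remains open, and an amine or a carboxylic acid in place of the bromo would test that. The compounds shown also leave open whether any single change to the shared core gives a step beyond the scatter.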